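Trifluoromethyl to Methoxymethyl: An Expected Value for Compound 4

The source may report more compounds than this note shows. Statements on the series, on what has been measured and on what is new or still open speak of the compounds shown alone.

Three compounds have been measured in a functional assay on CHO cells for agonist activity at prostaglandin E2 receptor EP4 subtype (Rattus norvegicus), read by cAMP accumulation and immunoassay, with a stated time of 10 min; a higher number here means that more compound is needed for the effect, a lower number that less compound is needed:
Compound 1, `O=C(O)CCCSCCN1C(=O)OC[C@@H]1/C=C/[C@@H](O)Cc1cccc(C(F)(F)F)c1`: 12 nM
Compound 2, `O=C(O)CCCSCCN1C(=O)SC[C@@H]1/C=C/[C@@H](O)Cc1cccc(C(F)(F)F)c1`: 4.3 nM
Compound 3, `COCc1cccc(C[C@H](O)/C=C/[C@H]2COC(=O)N2CCSCCCC(=O)O)c1`: 24 nM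

Compound 1 and compound 3 share one core and differ in a single place, (methoxymethyl in place of trifluoromethyl on an aromatic carbon). That change gave a 2.0-fold higher number from compound 1 to compound 3 (0.30 log units; within the scatter). Compound 2 is built on another core; the difference between the two cores is not broken down here. In this assay compound 2 gives the lowest of the three numbers, and its steps to the other two lie beyond the scatter. Compound 4, `COCc1cccc(C[C@H](O)/C=C/[C@H]2CSC(=O)N2CCSCCCC(=O)O)c1`, has not yet been measured. It stands to compound 2 as compound 3 stands to compound 1: methoxymethyl in place of trifluoromethyl on an aromatic carbon. Because the same change produced a 2.0-fold higher number from compound 1 to compound 3 (0.30 log units; within the scatter), a step of similar size is expected here: a 2.0-fold higher number from compound 2 to compound 4 (0.30 log units; within the scatter). Compound 4 is therefore estimated at 8.6 nM in this assay, most likely between 4 nM and 20 nM.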

Compound 4, half-maximal effective concentration: 2.4 nM
Compound 4: middle estimate off by 3.6-fold (0.55 log units), on the high side, outside the stated range (below it).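

In this assay, replacing trifluoromethyl with methoxymethyl gave a 1.8-fold lower number from compound 2 to compound 4 (0.25 log units; within the scatter). Set beside the same change on the core of compound 1, the two steps do not agree: the same change on two cores in this assay, a 2.0-fold higher number (0.30 log units; within the scatter) from compound 1 to compound 3 and a 1.8-fold lower number (0.25 log units; within the scatter) from compound 2 to compound 4, 3.6-fold (0.55 log units) apart, beyond the scatter of two such steps Each step on its own lies within the scatter, so these two pairs show that the size of this change cannot simply be carried from one core to the other, but they do not show that it truly acts in opposite directions on the two cores.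

The compounds shown leave open how other groups at this place, such as a methoxy group, a chlorine atom or a longer ether chain, would behave on each core.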